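Swapping Naphthalen-1-yl for 4-Phenylphenyl on a Shared Core

A few compounds are considered here, and "the series" means these few. Any claim that something is new, unique, unknown or untested is made for them only; others in the source may bear on it.

Of the compounds shown here, three on one core have been tested in an assay on isolated protein for inhibition of tyrosine-protein phosphatase non-receptor type 13 (Homo sapiens), read by spectrophotometry; on this read-out higher numbers stand for weaker inhibition and lower numbers for stronger inhibition. Compound 1 `O=C(COc1ccc2cc(C(O)(C(F)(F)F)C(F)(F)F)c(O)cc2c1)Nc1nc2ccccc2s1` carries a 1,3-benzothiazol-2-yl group on the amide-type nitrogen and in this assay gives 9900 nM. Compound 2 `CCCNC(=O)COc1ccc2cc(C(O)(C(F)(F)F)C(F)(F)F)c(O)cc2c1` bears a propyl group at that nitrogen. For compound 2 this assay reports only a limit, > 20000 nM. Compound 3 `O=C(COc1ccc2cc(C(O)(C(F)(F)F)C(F)(F)F)c(O)cc2c1)Nc1cccc2ccccc12` has a naphthalen-1-yl group at the same nitrogen. For compound 3 too this assay gives only a limit, > 20000 nM, so compound 3 stands at the top edge of what the numbers can show, together with one other value, as the limit of > 20000 nM in this assay, at which 2 of the 3 values shown sit, records. The steps read an at least 2.0-fold higher number from compound 1 to compound 2 (0.30 log units; that floor lies within the scatter), an at least 2.0-fold higher number from compound 1 to compound 3 (0.30 log units; that floor lies within the scatter) and a step that the two limits leave unreadable from compound 2 to compound 3.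

Compound 4 `O=C(COc1ccc2cc(C(O)(C(F)(F)F)C(F)(F)F)c(O)cc2c1)Nc1ccc(-c2ccccc2)cc1` differs from compound 3 in one place: 4-phenylphenyl in place of naphthalen-1-yl on an amide-type nitrogen. Among the measured compounds shown here, the steps that bear on it are the move from compound 1 to compound 3 and the unreadable one from compound 2 to compound 3, both ending at the limit. Since compound 3 itself is a limit, the step from compound 3 to compound 4 is expected to be a number no higher from compound 3 to compound 4 (the limit leaves the size open), with no direction that can be read beyond the scatter. Compound 4 is therefore estimated at 20000 nM, within 7000 nM to 60000 nM, and is expected most likely to be reported as a limit again.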

Compound 4, half-maximal inhibitory concentration: 2800 nM
Compound 4: middle estimate off by 7.1-fold (0.85 log units), on the high side; measured number outside the range, below it.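

At the amide-type nitrogen, two groups that each hold 2 six-membered aromatic rings of carbon only and no hydrogen-bond donors or acceptors are not interchangeable in this assay: placing 4-phenylphenyl where naphthalen-1-yl stood gives an at least 7.1-fold lower number from compound 3 to compound 4 (0.85 log units; beyond the scatter). A purely carbon aromatic group also separates clearly from the propyl group at this nitrogen, with an at least 7.1-fold lower number from compound 2 to compound 4 (0.85 log units; beyond the scatter), so a readable value here does not require the 1,3-benzothiazol-2-yl group. The new group goes further than that one, with a 3.5-fold lower number from compound 1 to compound 4 (0.55 log units; beyond the scatter), which makes compound 4 the strongest inhibitor of the four shown.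

As far as these compounds go, the step between compound 2 and compound 3 cannot be read, and neither can the true size of the steps that start from those two compounds, since both compounds remain at a limit of the assay: the limit of > 20000 nM in this assay, at which 2 of the 4 values shown sit. It remains open whether a carboxylic acid or an amine added to the 4-phenylphenyl group would raise or lower the number, and whether the step seen here would carry over to a different core.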